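A few compounds are considered here, and "the series" means these few. Any claim that something is new, unique, unknown or untested is made for them only; others in the source may bear on it.

Values so far in a functional assay on Jurkat cells (Homo sapiens) for antiproliferative activity, read by MTT assay, with a stated time of 72 h; a lower number here means a stronger inhibitor, a higher number a weaker inhibitor:
- compound 1 `COc1cc(C(=O)c2sc3ccccc3c2-c2ccc(Cl)cc2)cc(OC)c1OC` gives 3700 nM
- compound 2 `COc1cc(C(=O)c2sc3ccccc3c2-c2ccc(C)cc2)cc(OC)c1OC` gives 3300 nM

Within the data shown here, compound 2 stands level with compound 1, and the only measured step, a 1.1-fold lower number from compound 1 to compound 2 (0.05 log units; within the scatter), gives no ranking between them. Compound 3 `COc1cc(C(=O)c2sc3ccccc3c2-c2ccc(SC)cc2)cc(OC)c1OC` carries the next change, (methylsulfanyl in place of methyl on an aromatic carbon), which is methylsulfanyl in place of methyl on an aromatic carbon. Among the measured compounds shown here, that same step, methyl in place of chloro on an aromatic carbon, is the only evidence bearing on this change, and it stayed small. For the measured compounds named here, no compound with methylsulfanyl has been measured, so one step is a thin guide. No step beyond the scatter is therefore expected in this assay, in either direction. The expected step is a 1.1-fold lower number from compound 2 to compound 3 (0.04 log units; within the scatter) as an estimate. For compound 3 the estimated value is 3000 nM, with an expected range from 1200 nM to 8000 nM around it.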

Compound 3, half-maximal inhibitory concentration: 1900 nM
The estimate for compound 3 lay 1.6-fold (0.20 log units) above the measured number; measured number inside the range.
By their numbers in this assay, from the lowest: compounds 3, 2 and 1 (each within the scatter of the next).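

At this position, para to a large group, three groups can now be compared in this assay: chloro, methyl and methylsulfanyl. Among these compounds, the step to the two-atom methylsulfanyl stays within the scatter from methyl (a 1.7-fold lower number from compound 2 to compound 3 (0.24 log units; within the scatter)) and from chloro (a 1.9-fold lower number from compound 1 to compound 3 (0.29 log units; within the scatter)), so the series so far shows no ranking among the three and no loss on moving to a group that contains sulfur. No measurement is available to explain these results or to separate the contribution of the sulfur from that of the added carbon. From the compounds shown here alone, it remains open whether an amine, a carboxylic acid or a longer chain such as ethylsulfanyl would give a step beyond the scatter here. The three compounds also leave open whether a hydroxyl at this position would stay within it.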